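A few compounds are considered here, and "the series" means these few. Any claim that something is new, unique, unknown or untested is made for them only; others in the source may bear on it.

Measured compounds:
- compound 1 `CC1(C)CC(NC(=S)Nc2ccc(C#N)cc2)c2cc(Cl)ccc2O1`: 10000 nM
- compound 2 `CC1(C)CC(NC(=S)Nc2ccccc2)c2cc(Cl)ccc2O1`: 46000 nM

Both values come from a functional assay on U-373MG ATCC cells (Homo sapiens) for inhibition, read by MTT assay, with a stated time of 72 h; on this read-out lower numbers stand for stronger inhibition and higher numbers for weaker inhibition. Of the two, compound 2 has the higher number, at 46000 nM. Compound 3 `CC1(C)CC(NC(=S)NCc2ccccc2)c2cc(Cl)ccc2O1` has benzyl in place of phenyl on an amide-type nitrogen. Going by the values given here, the only measured step, a 4.6-fold higher number from compound 1 to compound 2 (0.66 log units; beyond the scatter), is modest. It is hydrogen in place of cyano on an aromatic carbon, so it leaves that nitrogen untouched and bears on the change only loosely. It indicates no direction, and no shift beyond the scatter is expected. The expected step is a 1.2-fold lower number from compound 2 to compound 3 (0.06 log units; within the scatter). For compound 3 the estimate is 40000 nM, with an expected range of 12000 nM to 100000 nM.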

Compound 3, half-maximal inhibitory concentration: 64000 nM
Beside the measured number, compound 3's estimate is 1.6-fold (0.20 log units) below it; the measured number falls inside the stated range.
By their numbers in this assay, from the lowest: compound 1; then compounds 2 and 3 (each within the scatter of the next).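

In this assay, benzyl in place of phenyl on the amide-type nitrogen gives a 1.4-fold higher number from compound 2 to compound 3 (0.14 log units; within the scatter), so the change from anilino to benzylamino does not separate these two compounds. Benzyl in place of 4-cyanophenyl at the same nitrogen gives a 6.4-fold higher number from compound 1 to compound 3 (0.81 log units; beyond the scatter), which leaves compound 1 apart from both of the groups without a nitrile. Nothing available explains either step. As far as these compounds go, it remains open whether 4-cyanobenzyl on this nitrogen would bring the number close to that of compound 1, and how a phenethyl or methyl group there would read.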